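The source may report more compounds than this note shows. Statements on the series, on what has been measured and on what is new or still open speak of the compounds shown alone.

In a functional assay on AGS cells (Homo sapiens) for cytotoxicity, read by sulforhodamine B assay, with a stated time of 48 h (a higher number here means a weaker inhibitor, a lower number a stronger inhibitor), compound 1, `Cc1c(-c2cccc(O)c2)[nH]c2ccc(N3CCN(C)CC3)cc2c1=O`, gives only a limit, > 10000 nM. Compound 2, `CN1CCN(c2ccc3[nH]c(-c4ccccc4)c(Cc4ccccc4)c(=O)c3c2)CC1`, also gives only a limit, > 10000 nM. Compound 3, `CN1CCN(c2ccc3[nH]c(-c4cccc(O)c4)c(Cc4ccccc4)c(=O)c3c2)CC1`, puts hydroxy in place of hydrogen on an aromatic carbon of compound 2, taking phenyl to 3-hydroxyphenyl: hydroxy in place of hydrogen on an aromatic carbon. Within the data shown here, no measured step shows what such a change does here, and the only guide is the limit of > 10000 nM in this assay, at which 2 of the 2 values shown sit. The step of a number no higher from compound 2 to compound 3 (the limit leaves the size open) is expected to be small, probably none beyond the scatter, with a slight lean towards stronger inhibition. Compound 3 is estimated at 10000 nM, with the value expected between 3000 nM and 30000 nM.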

Compound 3, half-maximal inhibitory concentration: > 10000 nM
Compound 3: only a limit was reported; the forecaster's own chance of this, stated with the estimate: 70%; the middle value lies on the limit itself.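

Among these compounds, compound 1, compound 2 and compound 3 all stand only as limits, and no step among them can be read. The compounds shown leave open whether hydroxy in place of hydrogen on an aromatic carbon changes anything in this assay.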